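The source may report more compounds than this note shows. Statements on the series, on what has been measured and on what is new or still open speak of the compounds shown alone.

Of the compounds shown here, three have so far been tested in a functional assay on AGS cells (Homo sapiens) for antiproliferative activity, read by MTT assay, with a stated time of 48 h; a lower number here means a stronger inhibitor of growth, a higher number a weaker inhibitor of growth. Compound 1 `COc1ccccc1OCCNc1cnn(Cc2ccc(OC)c(OCC3CC3)c2)c(=O)c1Cl` gives only a limit, > 100000 nM, the edge of what this assay can report (the limit of > 100000 nM in this assay, at which 1 of the 3 values shown sits). Compound 2 `COc1ccccc1OCCNc1ccc(=O)n(Cc2ccc(OC)c(OCC3CC3)c2)n1` gives 45800 nM, and compound 3 `COc1ccccc1OCCNc1ccc(=O)n(Cc2ccc(OC(F)F)c(OCC3CC3)c2)n1` gives 24400 nM. The move from compound 2 to compound 3 is difluoromethyl in place of methyl on an oxygen on an aromatic ring, and it brought a 1.9-fold lower number from compound 2 to compound 3 (0.27 log units; within the scatter). How the core of compound 1 differs from the core of compound 2 is not broken down here.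

Compound 4 `COc1ccccc1OCCNc1cnn(Cc2ccc(OC(F)F)c(OCC3CC3)c2)c(=O)c1Cl` differs from compound 1 by difluoromethyl in place of methyl on an oxygen on an aromatic ring, the same change at the same place. Because the earlier step, a 1.9-fold lower number from compound 2 to compound 3 (0.27 log units; within the scatter), was small, the step expected from compound 1 to compound 4 is a step that the limit leaves unreadable from compound 1 to compound 4. Compound 4 is therefore estimated at 120000 nM, within a range from 50000 nM to 400000 nM, and it may well again come back only as a limit.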

Compound 4, concentration for 50% growth inhibition: > 100000 nM
Compound 4 ended at the assay's limit (the forecaster's own chance of this, stated with the estimate: 70%); the middle value lies beyond the limit too.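

In this assay compound 1 and compound 4 both end at a limit, so no step between them can be read: the limit of > 100000 nM in this assay, at which 2 of the 4 values shown sit.

From the compounds shown here alone, whether methoxy to difluoromethoxy changes growth inhibition on the core of compound 1 stays open.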